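The compounds below may be only part of what the source reports. "The series", "measured", "known", "first", "only" and "open" are said of these compounds alone.

Among the measured compounds shown here, in an ADME assay on microsomes from liver (Homo sapiens) for metabolic stability, with a stated time of 10 min, tested at 0.5 uM (on this read-out lower numbers stand for a less stable compound and higher numbers for a more stable compound), compound 2 (`C[C@H](NC(=O)[C@H](C)[C@H]1CC[C@@H](c2ccnc3ccc(F)cc32)CC1)c1ccc(Cl)cc1`) gives 19%, the lower of the two numbers so far, while compound 1 (`COc1ncc(NC(=O)[C@H](C)[C@H]2CC[C@@H](c3ccnc4ccc(F)cc43)CC2)cn1`) gives 73%. Compound 3 (`C[C@@H](C(=O)NC1CCCCC1)[C@H]1CC[C@@H](c2ccnc3ccc(F)cc32)CC1`) has cyclohexyl in place of 1-(4-chlorophenyl)ethyl on an amide-type nitrogen. For the measured compounds named here, only one measured step bears on this change, the large a number 54 percentage points lower from compound 1 to compound 2 (beyond the scatter), which also alters the group on that nitrogen. It involves a different incoming group, so it is only a loose guide. The expected step is a modest rise, a number 16 percentage points higher from compound 2 to compound 3 (beyond the scatter). The estimate for compound 3 is 35%, with an expected range of 15% to 60%.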

Compound 3, percent of the compound remaining: < 1%
Compound 3: only a limit was reported (the forecaster's own chance of this, stated with the estimate: 2%); middle value at least 34 percentage points away from the limit.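

Cyclohexyl in place of 1-(4-chlorophenyl)ethyl on the amide-type nitrogen gives a number at least 18 percentage points lower from compound 2 to compound 3 (beyond the scatter), so removing the chlorine-bearing aromatic ring does not bring stability back. Cyclohexyl in place of 2-methoxypyrimidin-5-yl gives a number at least 72 percentage points lower from compound 1 to compound 3 (beyond the scatter), so two quite different groups now fall well short of the 2-methoxypyrimidin-5-yl group. The reading for compound 3 is a limit of the assay and not a number: the limit of < 1% in this assay, at which 1 of the 3 values shown sits.

Going by these compounds, it remains open whether a plain phenyl or a pyridyl on that nitrogen would keep the stability of compound 1. On these data alone, it is equally open whether the methoxy group contributes to that stability.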